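Removing One Fluorine from the Benzyl Group of Compound 2

This account rests on a few compounds, and the source may have more. Where it says the series, first, only, none or still open, it means among the compounds named here.

Three compounds share one core and differ only in the group attached to the aromatic nitrogen. Compound 1 `COc1cccc2c1c(C(=O)/C=C(\O)C(=O)O)cn2Cc1cc(F)ccc1F` gives 46200 nM in an ADME assay on MT4 cells (Homo sapiens) for cytotoxicity, read by MTT assay; a lower number here means that less compound is tolerated, a higher number that more compound is tolerated. Compound 2 `COc1cccc2c1c(C(=O)/C=C(\O)C(=O)O)cn2Cc1cc(F)cc(F)c1` gives 29500 nM, and compound 3 `COc1cccc2c1c(C(=O)/C=C(\O)C(=O)O)cn2Cc1cc(F)c(F)c(F)c1` gives 23300 nM. Of the three numbers, that of compound 2 sits in the middle, but both neighbours lie within the scatter: the nearest is compound 3, with a 1.3-fold lower number from compound 2 to compound 3 (0.10 log units; within the scatter), and the furthest is compound 1, with a 1.6-fold lower number from compound 1 to compound 2 (0.19 log units; within the scatter). Compound 1 to compound 3 shows a 2.0-fold lower number from compound 1 to compound 3 (0.30 log units; within the scatter).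

Compound 4 `COc1cccc2c1c(C(=O)/C=C(\O)C(=O)O)cn2Cc1cccc(F)c1` is the next step from compound 2: hydrogen in place of fluoro on an aromatic carbon. Among the compounds with values here, the one measured step that bears on it is the reverse of this change, fluoro entering for hydrogen, which gave a 1.3-fold lower number from compound 2 to compound 3 (0.10 log units; within the scatter). Taking a fluoro away is therefore expected to move the number, if at all, slightly upward, and no step among the measured compounds reached beyond the scatter. Compound 4 is thus expected to give 35000 nM in this assay, within a range of 18000 nM to 70000 nM. That estimate means an expected 1.2-fold higher number from compound 2 to compound 4 (0.07 log units; within the scatter), still within the scatter.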

Compound 4, half-maximal cytotoxic concentration: 65800 nM
Beside the measured number, compound 4's estimate is 1.9-fold (0.27 log units) below it; measured number inside the range.
By their numbers in this assay, from the lowest: compounds 3, 2, 1 and 4 (each within the scatter of the next, the first and the last beyond it).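

In this assay, within the data shown here, compound 4 supplies the only steps that pass the scatter, both modest: a 2.2-fold higher number from compound 2 to compound 4 (0.35 log units; beyond the scatter) and a 2.8-fold higher number from compound 3 to compound 4 (0.45 log units; beyond the scatter). Thus hydrogen in place of fluoro on the 3,5-difluorobenzyl group gives a change that can be read, which no comparison among the earlier compounds did, but the same kind of change starting from the 2,5-difluorobenzyl group does not pass the scatter, with a 1.4-fold higher number from compound 1 to compound 4 (0.15 log units; within the scatter). Read in the other direction, fluoro in place of hydrogen gives steps that agree on the two different partners, though neither step alone can be told from the scatter: the same change on two cores in this assay, a 1.3-fold lower number (0.10 log units; within the scatter) from compound 2 to compound 3 and a 1.4-fold lower number (0.15 log units; within the scatter) from compound 4 to compound 1, 1.1-fold (0.05 log units) apart, within the scatter of two such steps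

The compounds shown leave open whether the upward shift follows the loss of fluoro as such, or would also appear with a chloro, methyl or methoxy group on that aromatic carbon. They also leave open how an unsubstituted benzyl group would stand in this assay, and so whether the one fluoro that remains in compound 4 matters at all.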